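Working notes: from compound 1 to compound 4

The compounds below may be only part of what the source reports. "The series", "measured", "known", "first", "only" and "open" are said of these compounds alone.

- compound 1 `OC(c1cccs1)c1cc2ccccc2nc1Cl` gives 17500 nM
- compound 2 `Cc1ccc(-c2cc(COC(c3cccs3)c3cc4ccccc4nc3Cl)on2)cc1` gives "not active" (no number reported)
- compound 3 `FC(F)(F)c1cccc(COC(c2cccs2)c2cc3ccccc3nc2Cl)c1` gives "not active" (no number reported)

Among the measured compounds shown here, in a functional assay on HeLa cells (Homo sapiens) for inhibition, read by WST assay, with stated times of 72 h and 2 h (on this read-out lower numbers stand for stronger inhibition and higher numbers for weaker inhibition), compound 1 gives 17500 nM and is the only entry with a number. Compound 4 `Fc1ccc(COC(c2cccs2)c2cc3ccccc3nc2Cl)cc1` is not yet measured. Its change from compound 1 is 4-fluorobenzyl in place of hydrogen on an oxygen on a saturated carbon with 4-fluorobenzyl in place of hydrogen on an oxygen on a saturated carbon. For the measured compounds named here, no measured step is available for comparison. That hydrogen is also replaced in compound 2 and compound 3. Compound 2 reads "not active" (no number reported) and compound 3 reads "not active" (no number reported) in this assay so a step towards weaker inhibition is expected. The estimated 2.3-fold higher number from compound 1 to compound 4 (0.36 log units; beyond the scatter) may yet end without any number. The estimate for compound 4 is 40000 nM with an expected range of 15000 nM to 100000 nM around it.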

Compound 4, half-maximal inhibitory concentration: 73900 nM
Compound 4: middle estimate off by 1.8-fold (0.27 log units), on the low side; low and high end bracket the measured number.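

In this assay, 4-fluorobenzyl in place of hydrogen on this oxygen gives a 4.2-fold higher number from compound 1 to compound 4 (0.63 log units; beyond the scatter) and still leaves a measurable number. Among the compounds shown here, compound 2 and compound 3 carry other groups on the same oxygen and read "not active", so their steps cannot be read, and this is the only sized change at this position. No measurement at hand accounts for the weaker inhibition.

Still open, from the compounds shown here alone, is whether a small methyl group or a chain ending in an amine on this oxygen would give a number nearer that of compound 1. Going by these compounds, the part played by the fluorine in compound 4 also remains open.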